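A few compounds are considered here, and "the series" means these few. Any claim that something is new, unique, unknown or untested is made for them only; others in the source may bear on it.

The measured compounds:
Compound 1, `Cc1cc(-c2ccc(Oc3ccnc(Nc4ccc(C#N)cc4)n3)c(F)c2)ccc1C#N`: in a functional assay on MT4 cells (Homo sapiens) for cytotoxicity, read by MTT assay, with a stated time of 5 days (on this read-out lower numbers stand for higher toxicity in this test and higher numbers for lower toxicity in this test), compound 1 gives > 296000 nM, which is a limit of the test rather than a number.
Compound 2, `N#Cc1ccc(Nc2nccc(Oc3ccc(-c4ccc(C#N)cc4F)cc3F)n2)cc1`: in this assay compound 2 gives > 294000 nM, again a limit.
Compound 3, `Cc1cc(-c2ccc(C#N)cc2F)ccc1Oc1ccnc(Nc2ccc(C#N)cc2)n1`: in this assay compound 3 gives > 296000 nM, also a limit.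

Compound 3 thus stands where the whole set stands: at a limit, with no measured number behind it. Two of the three values sit at the limit of > 296000 nM in this assay, at which 2 of the 3 values shown sit, and one at the limit of > 294000 nM in this assay, at which 1 of the 3 values shown sits, so none of them can be placed in order against another. The step that the two limits leave unreadable from compound 1 to compound 2 and the step that the two limits leave unreadable from compound 2 to compound 3 are both left unreadable by these limits, and neither gives a size that could be carried forward.

The unmeasured compound 4, `Cc1cc(-c2ccc(C#N)c(F)c2)ccc1Oc1ccnc(Nc2ccc(C#N)cc2)n1`, differs from compound 3 by 4-cyano-3-fluorophenyl in place of 4-cyano-2-fluorophenyl on an aromatic carbon. The two measured steps, being unreadable, bear on this change only in that every compound in the series, whatever was altered, stayed at the limit. On that basis the step of a number no higher from compound 3 to compound 4 (the limit leaves the size open) is expected to be none beyond the scatter, with compound 4 most likely reported again as a limit in this assay. The estimate for compound 4 is 296000 nM, within the range 150000 nM to 600000 nM.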

Compound 4, half-maximal cytotoxic concentration: > 296000 nM
Compound 4: a limit, no number (the forecaster's own chance of this, stated with the estimate: 85%); the middle value lies on the limit itself.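

In this assay compound 4 gives > 296000 nM, which is a limit of the test and not a number. Within the data shown here, compound 3 also stands at a limit, so no step from compound 3 to compound 4 can be read. The compounds shown leave open where the real cytotoxic concentration of any of them lies, and whether 4-cyano-3-fluorophenyl in place of 4-cyano-2-fluorophenyl changes it at all.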